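Adding a Methoxy Group to a Weakly Antiproliferative Quinoline

This account rests on a few compounds, and the source may have more. Where it says the series, first, only, none or still open, it means among the compounds named here.

Of the compounds shown here, three have been tested in a functional assay on MCF-10A cells (Homo sapiens) for antiproliferative activity, with a stated time of 48 h; on this read-out higher numbers stand for an effect only at larger amounts of compound and lower numbers for an effect already at smaller amounts. Compound 1 `COc1ccc2nc(C)cc(NCc3cccc(F)c3)c2c1` gives 14700 nM, compound 2 `COc1ccc2nc(C)cc(NCc3ccc(OC)c(F)c3)c2c1` gives 10300 nM, and compound 3 `Cc1cc(NCc2ccc(F)cc2)c2ccccc2n1` gives 20100 nM. All three values lie within the usual scatter of one another, so none of them can be called stronger or weaker than the others.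

Compound 2 differs from compound 1 by one change, (methoxy in place of hydrogen on an aromatic carbon), which brought a 1.4-fold lower number from compound 1 to compound 2 (0.15 log units; within the scatter). The difference between the core of compound 1 and the core of compound 3 is not broken down here.

Compound 4 `COc1ccc2c(NCc3ccc(F)cc3)cc(C)nc2c1` has not yet been measured. It differs from compound 3 by methoxy in place of hydrogen on an aromatic carbon. Going by the values given here, this is the same kind of change as the one from compound 1 to compound 2, but not the same: there the methoxy entered ortho to a fluoro group and para to a large group, whereas here it enters on a fused ring, meta and para to a fused ring.

For compound 4 a step of about a 1.4-fold lower number from compound 3 to compound 4 (0.16 log units; within the scatter) is expected in this assay, resting on the small step from compound 1 to compound 2 of a 1.4-fold lower number from compound 1 to compound 2 (0.15 log units; within the scatter). Compound 4 is therefore estimated at 14000 nM, within 7000 nM to 28000 nM.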

Compound 4, half-maximal effective concentration: 15900 nM
For compound 4 the middle estimate is 1.1-fold (0.06 log units) below the measured one; the range from low to high includes it.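

Putting methoxy in place of hydrogen on an aromatic carbon gave a 1.3-fold lower number from compound 3 to compound 4 (0.10 log units; within the scatter) in this assay. On these two cores the change behaves alike, with no difference between the two steps that can be told from the usual noise of the measurement: the same change on two cores in this assay, a 1.4-fold lower number (0.15 log units; within the scatter) from compound 1 to compound 2 and a 1.3-fold lower number (0.10 log units; within the scatter) from compound 3 to compound 4, 1.1-fold (0.05 log units) apart, within the scatter of two such steps. This does not show that methoxy truly lowers the number, as each step on its own lies within the scatter, and it gives no rule for the whole series, as two pairs of compounds are few and the methoxy enters at a different kind of place in each.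

The compounds shown leave open whether another group on that same aromatic carbon, such as an amine, a carboxylic acid or a longer chain, would bring a step beyond the scatter. They also leave open whether methoxy would do so on any core other than these two.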